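A few compounds are considered here, and "the series" means these few. Any claim that something is new, unique, unknown or untested is made for them only; others in the source may bear on it.

Measured compounds:
- compound 1 `O=C(O)CCCCCOc1cc(-c2ccccc2)cc(-c2ccc(F)cc2)n1`: > 10000 nM in a functional assay on cells for inhibition of leukotriene B4 receptor 1 (Homo sapiens); a higher number here means a weaker inhibitor, a lower number a stronger inhibitor
- compound 2 `CC(CCCCOc1cc(-c2ccccc2)cc(-c2ccccc2F)n1)C(=O)O`: 70 nM in this assay

In this assay compound 1 gives only a limit, > 10000 nM, and not a number. Within the data shown here, compound 2 gives 70 nM, the only number among the two values shown, and so compound 2 is the sole point of reference here. Compound 1 and compound 2 differ in more than one place, so their two values show only that one is a limit and the other a number; no single step can be read from them.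

Compound 3 `CC(CCCCOc1cc(-c2ccccc2)cc(-c2ccccc2)n1)C(=O)O` has not yet been measured. It differs from compound 2 as follows: hydrogen in place of fluoro on an aromatic carbon. With no measured step of this kind among the compounds shown, the size of the change can only be guessed. A single hydrogen in place of fluoro on an aromatic carbon is a small change, and the step from compound 2 to compound 3 is expected to be modest, most likely a slight loss or none beyond the scatter, a 1.6-fold higher number from compound 2 to compound 3 (0.20 log units; within the scatter). Compound 3 is therefore expected to give about 110 nM in this assay, in a range from 35 nM to 350 nM.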

Compound 3, half-maximal inhibitory concentration: 22 nM
The estimate for compound 3 lay 5.0-fold (0.70 log units) above the measured number; measured number below the stated range.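

Going from 2-fluorophenyl to phenyl, on an aromatic carbon ortho to a large group, gives a 3.2-fold lower number from compound 2 to compound 3 (0.50 log units; beyond the scatter) in this assay, and this is the first single change in the series that can be read. It shows that the fluoro is not needed at this position for the activity seen here: compound 3, which carries only hydrogen there, has the lower number, and this one place alone moves the value beyond the scatter. Nothing measured here bears on why the step runs in this direction.

From the compounds shown here alone, whether chloro, methoxy or an amine at this position, or fluoro elsewhere on the same ring, would lower the number further stays open, as does the part played by the chain that carries the carboxylic acid. Among these compounds, compound 1 gives only a limit, > 10000 nM, which is not a number, and no step to it can be read.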